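The source may report more compounds than this note shows. Statements on the series, on what has been measured and on what is new or still open speak of the compounds shown alone.

Measured so far:
compound 1 `COc1ccc2nc(C)cc(OCC(=O)Nc3ccccc3)c2c1`: 4.28
compound 2 `COc1ccc2nc(C)cc(OCC(=O)Nc3cc(OC)c(OC)c(OC)c3)c2c1`: 3.95

Both compounds sit on the shared core and were read in a physicochemical assay for lipophilicity, read by HPLC, in phosphate buffer, measured as chromatographic lipophilicity, at pH 7.4; on this read-out lower numbers stand for lower lipophilicity and higher numbers for higher lipophilicity. Compound 1 gives 4.28, the higher of the two numbers, while compound 2 gives 3.95, a value that lies lower by more than the usual scatter. No single-group change between two measured compounds is available, so the move to compound 3 `COc1ccc2nc(C)cc(OCC(=O)NNC(=O)c3ccncc3)c2c1` rests on the structural change alone: ((pyridin-4-yl)carbonyl)amino in place of phenyl on an amide-type nitrogen. A ring of carbon only leaves, and the entering group brings a hydrogen-bond donor and hydrogen-bond acceptors where the phenyl brought none. Such a change is expected to push the read-out in this assay downward by a step well beyond the scatter, the estimated step being a number 1.88 log units lower from compound 1 to compound 3 (beyond the scatter). Compound 3 is accordingly estimated at 2.4, within a range from 1.7 to 3.1.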

Compound 3, distribution coefficient: 1.48
For compound 3 the middle estimate is 0.92 log units above the measured one; the whole stated range lies above it.
By their numbers in this assay, from the lowest: compound 3; then compound 2; then compound 1.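

Replacing phenyl with ((pyridin-4-yl)carbonyl)amino on an amide-type nitrogen moves the read-out of this assay by a large amount: a number 2.80 log units lower from compound 1 to compound 3 (beyond the scatter). The earlier compounds shown here offered no single-group change, so this is the only measured size for a change at this position, and it shows that the read-out there can respond strongly. The entering group differs from phenyl in several ways at once, including its hetero atom in the ring, its carbonyl, and its hydrogen-bond donor and acceptors, and no measurement here explains the size of the step.

It remains open which of these parts accounts for the step. A benzoylamino group, with its ring of carbon only, or a plain amine on the same nitrogen could help to separate them.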